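Compound 4: a sulfoximine replaces the fluorinated carbinol

This account rests on a few compounds, and the source may have more. Where it says the series, first, only, none or still open, it means among the compounds named here.

Compound 1 `CC#C[C@H]1CN(S(=O)(=O)c2ccc(N)nc2)CCN1c1ccc([C@@](O)(CO)C(F)(F)F)cc1` is the reference point of the series. In an assay on cells (Hepatocyte) for inhibition of glucokinase regulatory protein (Mus musculus), with stated times of 20 min and 40 min (a higher number here means that more compound is needed for the effect, a lower number that less compound is needed), compound 1 gives 89 nM, and on the numbers shown it is the only compound with a measured value rather than a limit. Compound 2 `CC#C[C@H]1CN(S(=O)(=O)c2ccc(N)nc2)CCN1c1ncc(C(C)(O)C(F)(F)F)s1` in this assay gives > 12500 nM, which is a limit of the assay. Compound 3 `CC#C[C@H]1CN(S(=O)(=O)c2ccc(N)nc2)CCN1c1ncc(C(O)(C(F)(F)F)C(F)(F)F)s1` in this assay gives > 12500 nM, again a limit. Among the measured compounds shown here, the single measured step, a step that the two limits leave unreadable from compound 2 to compound 3, therefore cannot be read, since both ends sit at the limit of > 12500 nM in this assay, at which 2 of the 3 values shown sit.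

Compound 4 `CC#C[C@H]1CN(S(=O)(=O)c2ccc(N)nc2)CCN1c1ccc(S(=N)(=O)C2CC2)cc1` differs from compound 1 by a group of 6 heavy atoms (3 carbon, 1 nitrogen, 1 oxygen, 1 sulfur; one three-membered non-aromatic ring of carbon only) in place of a group of 8 heavy atoms (3 carbon, 2 oxygen, 3 fluorine; no ring), on an aromatic carbon. The change sits on the same six-membered aromatic ring of carbon only as in compound 1, para to a large group.

No measured step bears on this change: the one shown step concerns compounds 2 and 3, which carry a different ring and give only limits, and nothing connects compound 1 to either of them by a single change. The expectation for compound 4 thus rests on compound 1 alone and on the fact that the shared core is kept intact.

Compound 4 is expected to remain a measurable compound in this assay, with an estimated 80 nM (range 25 nM to 300 nM), a step of a 1.1-fold lower number from compound 1 to compound 4 (0.05 log units; within the scatter) that is expected to lie within the usual scatter.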

Compound 4, half-maximal effective concentration: 208 nM
For compound 4 the middle estimate is 2.6-fold (0.41 log units) below the measured one, and the stated range covers the measured number.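

In this assay, the sulfoximine group of 6 heavy atoms can stand in for the fluorinated carbinol on this aromatic carbon, para to a large group, with only a modest loss: a 2.3-fold higher number from compound 1 to compound 4 (0.37 log units; beyond the scatter). The group that enters has no fluorine and no defined stereocentre, so neither feature of the group that leaves is required for a measured value at this position with the core of compound 1 kept intact. Compound 4 adds a second measured number to the series, and the only readable step so far is the one linking it to compound 1, while the remaining values are limits of the assay and not numbers: the limit of > 12500 nM in this assay, at which 2 of the 4 values shown sit.

The whole group changes in this single step, so the shift cannot be assigned to the sulfur centre, the ring of three carbons or the loss of the hydroxyl groups. Also open, going by these compounds, is how this position would respond to a sulfone, a carboxylic acid or an amine, and whether the sulfoximine would give a measured value on the ring carried by compounds 2 and 3.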